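Replacing the methoxyphenyl amide with a benzyl amide

The compounds below may be only part of what the source reports. "The series", "measured", "known", "first", "only" and "open" are said of these compounds alone.

Among the measured compounds shown here, in a functional assay on HepG2 cells (Homo sapiens) for inhibition, read by MTT assay, with a stated time of 72 h (on this read-out lower numbers stand for stronger inhibition and higher numbers for weaker inhibition), compound 1 `COc1cccc(NC(=O)C2CCN(C/C=C/c3ccccc3)CC2)c1` gives 78600 nM, the highest of the three numbers measured so far. Compound 2 `O=C(Nc1cccc(C(F)(F)F)c1)C1CCN(C/C=C/c2ccccc2)CC1` gives 11400 nM in this assay, and compound 3 `O=C(Nc1nc2ccc(Br)cc2s1)C1CCN(C/C=C/c2ccccc2)CC1` gives 32100 nM. For the measured compounds named here, the one single-point step measured, a 6.9-fold lower number from compound 1 to compound 2 (0.84 log units; beyond the scatter), shows that changing the group on the amide-type nitrogen can move the number well beyond the scatter. Compound 4 `O=C(NCc1ccccc1)C1CCN(C/C=C/c2ccccc2)CC1` differs from compound 1 by benzyl in place of 3-methoxyphenyl on an amide-type nitrogen. Going by the values given here, no measured step covers this exact change, so the direction is uncertain; a modest fall in the number, like the one seen in compound 2, seems plausible but not assured. Compound 4 is therefore expected to reach about 40000 nM, between 10000 nM and 150000 nM, which amounts to an estimated 2.0-fold lower number from compound 1 to compound 4 (0.29 log units; within the scatter).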

Compound 4, half-maximal inhibitory concentration: > 100000 nM
Compound 4 was reported as a limit; the forecaster's own chance of this, stated with the estimate: 25%; middle value at least 2.5-fold (0.39 log units) from the limit.
By their numbers in this assay, from the lowest: compound 2; then compound 3; then compound 1. At a limit, above all of these: compound 4.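

In this assay, compound 4 is reported only as a limit, not as a number: the limit of > 100000 nM in this assay, at which 1 of the 4 values shown sits. Benzyl in place of 3-methoxyphenyl on the amide-type nitrogen gives an at least 1.2-fold higher number from compound 1 to compound 4 (0.10 log units; that floor lies within the scatter), so the true size of the step cannot be read and a rise is not established. Unlike the step to trifluoromethyl, this change brings no fall in the number, so a new group at this place does not always lower it. Still open, from the compounds shown here alone, is whether an amine, a carboxylic acid or a longer chain such as phenethyl on this nitrogen would lower the number.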